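From 4-nitrophenyl to thiophen-3-yl on the shared core

A few compounds are considered here, and "the series" means these few. Any claim that something is new, unique, unknown or untested is made for them only; others in the source may bear on it.

Within the data shown here, in an ADME assay on MDCK cells (Canis lupus familiaris) for cytotoxicity, read by MTT assay, with a stated time of 48 h (a lower number here means that less compound is tolerated, a higher number that more compound is tolerated), compound 3 (`O=[N+]([O-])c1ccc(-c2cn(CC3=C(Cl)c4ccc(-c5cccs5)nc4CC3)nn2)cc1`) gives 40 ug/mL, the only true number among the three compounds measured. Compound 1 (`COc1ccc(-c2cn(CC3=C(Cl)c4ccc(-c5cccs5)nc4CC3)nn2)cc1`) is reported at > 300 ug/mL, which is a limit of the assay and not a number. Compound 2 (`ClC1=C(Cn2cc(-c3ccc(Cl)c(Cl)c3)nn2)CCc2nc(-c3cccs3)ccc21`) is reported at > 300 ug/mL, again a limit.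

Compound 4 (`ClC1=C(Cn2cc(-c3ccsc3)nn2)CCc2nc(-c3cccs3)ccc21`) has thiophen-3-yl in place of 4-nitrophenyl on an aromatic carbon of a five-membered aromatic ring with 3 nitrogen: thiophen-3-yl in place of 4-nitrophenyl on an aromatic carbon. Two measured steps change the group at this same place and bear directly on the comparison: an at least 7.5-fold lower number from compound 1 to compound 3 (0.87 log units; beyond the scatter) and an at least 7.5-fold lower number from compound 2 to compound 3 (0.87 log units; beyond the scatter). Both lie beyond the scatter and both end at the 4-nitrophenyl group. The remaining step, a step that the two limits leave unreadable from compound 1 to compound 2, gives no size to work with. Thiophen-3-yl has not been measured at this place, so the reading rests on the group that leaves. With an at least 7.5-fold lower number from compound 1 to compound 3 (0.87 log units; beyond the scatter) and an at least 7.5-fold lower number from compound 2 to compound 3 (0.87 log units; beyond the scatter) run in reverse, a rise of comparable size is expected in this assay. The expected move is a 7.5-fold higher number from compound 3 to compound 4 (0.88 log units; beyond the scatter). Compound 4 is estimated at 300 ug/mL, with an expected range of 100 ug/mL to 600 ug/mL.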

Compound 4, half-maximal cytotoxic concentration: > 300 ug/mL
Compound 4 ended at the assay's limit; the forecaster's own chance of this, stated with the estimate: 65%; the middle value sits exactly at the limit.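

In this assay the change is an at least 7.5-fold higher number from compound 3 to compound 4 (0.87 log units; beyond the scatter), so the low number of compound 3 now stands against a group that is not a substituted phenyl at all: thiophen-3-yl, a five-membered aromatic ring with 1 hetero atom. Among the four compounds on the shared core, only the 4-nitrophenyl group on this aromatic carbon of a five-membered aromatic ring with 3 nitrogen gives a value short of the limit, and no compound shown goes against that. The true size of the step remains unknown, because compound 4 stands at a limit of the assay and not at a number, as do two others: the limit of > 300 ug/mL in this assay, at which 3 of the 4 values shown sit.

The steps among compound 1, compound 2 and compound 4 cannot be read, so these three groups cannot be placed in any order in this assay. The compounds shown also do not tell whether the low number follows the nitro group itself or the whole 4-nitrophenyl group, a question that a nitro group carried on thiophen-3-yl, or an amine or a carboxylic acid in its place on the phenyl ring, would bear on.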